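A Second Chlorine on a Paw Edema Read-Out

This account rests on a few compounds, and the source may have more. Where it says the series, first, only, none or still open, it means among the compounds named here.

In a functional assay on the whole organism (strain Wister albino) for inhibition, with Rattus norvegicus as the target, read by paw edema, with a stated time of 1 h, at a dose of 50 mg/kg by the intraperitoneal route (on this read-out higher numbers stand for more inhibition at the one dose given (going by the name of the read-out) and lower numbers for less inhibition), compound 2 `CCOC(=O)c1c(-c2ccc(Cl)cc2)cc(-c2ccccc2)nc1Nc1ccc(C)cc1` gives 69.5%, the higher of the two numbers measured, while compound 1 `CCOC(=O)c1c(-c2ccc(Cl)c(Cl)c2)cc(-c2ccccc2)nc1N1CCCCC1` gives 53.5%, a gap beyond the usual scatter. Compound 3 `CCOC(=O)c1c(-c2ccc(Cl)c(Cl)c2)cc(-c2ccccc2)nc1Nc1ccc(C)cc1` has not yet been measured. It differs from compound 2 by chloro in place of hydrogen on an aromatic carbon, so that a 4-chlorophenyl becomes a 3,4-dichlorophenyl. Going by the values given here, no measured pair isolates this change on its own, so only a small step is expected, in neither direction beyond the scatter: a number 4.5 percentage points lower from compound 2 to compound 3 (within the scatter). Compound 3 is therefore estimated at 65%, most likely between 50% and 80%.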

Compound 3, a percentage reported as inhibition, in the whole organism at one dose (the size of the read-out at that dose, not a potency): 59%
Estimate against measurement, compound 3: 6 percentage points above; measured number inside the range.
By their numbers in this assay, from the lowest: compounds 1 and 3 (each within the scatter of the next); then compound 2.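

In this assay, the second chlorine, which turns 4-chlorophenyl into 3,4-dichlorophenyl, gives a number 10.5 percentage points lower from compound 2 to compound 3 (beyond the scatter), so this position on the ring is sensitive to even a single added heavy atom. With the 3,4-dichlorophenyl kept, (4-methylphenyl)amino in place of piperidin-1-yl gives a number 5.5 percentage points higher from compound 1 to compound 3 (within the scatter), so this swap does not separate the two groups on this read-out. Nothing shown here explains why the chlorine has this effect.

Open, on these data alone, is whether fluoro or methoxy at the same place would lower the number too. Also open, as far as these compounds go, is whether the second chlorine has the same effect when piperidin-1-yl is on the core.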